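Predicting Compound 4 from an Amide Substituent Exchange

The source may hold more compounds than are shown below. What is called first, only, known or untested is meant among the compounds shown, and "the series" means these compounds.

Compound 2 `COc1cccc(NC(=O)/C=C/c2coc3cc(OC)ccc3c2=O)c1` gives 39100 nM in a functional assay (QGY7701 cells, Homo sapiens) for inhibition, read by MTT assay, with a stated time of 48 h (on this read-out lower numbers stand for stronger inhibition and higher numbers for weaker inhibition), the lowest of the two numbers reported, while compound 1 `O=C(/C=C/c1coc2cc(O)ccc2c1=O)NCc1ccccc1` stands nearest with 63000 nM in this assay, a gap that lies within the scatter. Compound 3 `COc1ccc(NC(=O)/C=C/c2coc3cc(O)ccc3c2=O)cc1` returns only a limit of the assay in this assay, > 100000 nM. Among the measured compounds shown here, the single measured step on the amide nitrogen, an at least 1.5-fold higher number from compound 1 to compound 3 (0.20 log units; that floor lies within the scatter), ran into the limit (the limit of > 100000 nM in this assay, at which 1 of the 3 values shown sits), so only its floor is known, and that floor sits within the scatter.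

Compound 4 `COc1ccc2c(=O)c(/C=C/C(=O)Nc3ccccc3C)coc2c1` has not yet been measured. It differs from compound 2 in one place: 2-methylphenyl in place of 3-methoxyphenyl on an amide-type nitrogen. For the measured compounds named here, the step from compound 1 to compound 3 is the only evidence for exchanges on that nitrogen, and it points, if anywhere, toward a higher number, though its size is uncertain. The analyst expects the step of a 1.3-fold higher number from compound 2 to compound 4 (0.11 log units; within the scatter) to stay within the scatter or drift modestly toward weaker inhibition. The analyst's estimate for compound 4 in this assay is 50000 nM, with a range from 15000 nM to 160000 nM, and a real chance that the assay again reports only a limit.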

Compound 4, half-maximal inhibitory concentration: 22500 nM
Estimate against measurement, compound 4: 2.2-fold (0.35 log units) above; the measured number falls inside the stated range.
By their numbers in this assay, from the lowest: compounds 4, 2 and 1 (each within the scatter of the next, the first and the last beyond it). At a limit, above all of these: compound 3.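

In this assay, among the compounds shown here, the exchange of 3-methoxyphenyl for 2-methylphenyl on the amide-type nitrogen gives the first step at this position that can be read in full, a 1.7-fold lower number from compound 2 to compound 4 (0.24 log units; within the scatter), and that step stays within the scatter. The earlier exchange at this nitrogen yielded only a floor, since its end point, compound 3, is a limit of the assay and not a number: the limit of > 100000 nM in this assay, at which 1 of the 4 values shown sits. On the core shared by compound 2 and compound 4, the hydrogen-bond acceptor counted in 3-methoxyphenyl and absent from 2-methylphenyl can therefore go without a difference that rises beyond the scatter, although this rests on one pair and says nothing about the core of compound 1 or compound 3.

The two aryl groups in this pair do not show whether the same holds for 4-methoxyphenyl on the core of compound 2 and compound 4. From the compounds shown here alone, how this nitrogen would respond to something other than an aromatic ring, such as a carboxylic acid or a longer chain ending in an amine, also remains open.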